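Series notes: replacing the (2-cyanoethyl)(methyl)amino side chain

The source may report more compounds than this note shows. Statements on the series, on what has been measured and on what is new or still open speak of the compounds shown alone.

Compound 1 `CN(CCC#N)C[C@H]1CN(c2ccc(-n3cc(-c4ccccn4)cn3)c(F)c2)C(=O)O1` carries a (2-cyanoethyl)(methyl)amino group on a saturated chain carbon bound to a saturated ring carbon. Among the compounds with values here, in a physicochemical assay for lipophilicity, read by HPLC, measured as octanol-water partition (a lower number here means a more polar compound, a higher number a more lipophilic compound), compound 1 gives 1.9, the highest of the three numbers measured so far. Its nearest neighbour is compound 2 `O=C1O[C@@H](Cn2ccnc2)CN1c1ccc(-n2cc(-c3ccccn3)cn2)c(F)c1`, which in this assay gives 1.73; the gap to compound 1 is within the scatter, so no order between the two is claimed. Compound 3 `CS(=O)(=O)NC[C@H]1CN(c2ccc(-n3cc(-c4ccccn4)cn3)c(F)c2)C(=O)O1` gives 1.38 in this assay and sits furthest from compound 1.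

The measured steps are: a number 0.17 log units lower from compound 1 to compound 2 (within the scatter); a number 0.52 log units lower from compound 1 to compound 3 (beyond the scatter); a number 0.35 log units lower from compound 2 to compound 3 (beyond the scatter).

Compound 4 `COC(=O)NC[C@H]1CN(c2ccc(-n3cc(-c4ccccn4)cn3)c(F)c2)C(=O)O1` has not been measured. Relative to compound 1 the change is (methoxycarbonyl)amino in place of (2-cyanoethyl)(methyl)amino on a saturated chain carbon bound to a saturated ring carbon.

Both replacements of the (2-cyanoethyl)(methyl)amino group seen so far lowered the number, one within the scatter, one modestly beyond it. Within the data shown here, the new group, like the one in compound 3, is an uncharged group bearing a hydrogen-bond donor, so a step in the same direction as the step from compound 1 to compound 3 is expected, though perhaps somewhat smaller. Compound 4 is therefore expected to give about 1.5 in this assay, with a range from 1.2 to 1.8. The expected step is a number 0.40 log units lower from compound 1 to compound 4 (beyond the scatter), a modest decrease beyond the scatter.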

Compound 4, partition coefficient: 2.03
Compound 4: the middle estimate sits 0.53 log units below what was measured; measured number above the stated range.
By their numbers in this assay, from the lowest: compound 3; then compounds 2, 1 and 4 (each within the scatter of the next).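

In this assay, putting (methoxycarbonyl)amino in place of (2-cyanoethyl)(methyl)amino on a saturated chain carbon bound to a saturated ring carbon gives a number 0.13 log units higher from compound 1 to compound 4 (within the scatter) and so leaves no readable shift, which shows that an entering group bearing a hydrogen-bond donor does not by itself set the number at this position. Within the data shown here, the contrast lies instead in what sits on the amine nitrogen: methoxycarbonyl in place of methylsulfonyl gives a number 0.65 log units higher from compound 3 to compound 4 (beyond the scatter) and leaves compound 3 as the one compound whose steps to all three others are printed as beyond the scatter. The change to (methoxycarbonyl)amino from 1H-imidazol-1-yl gives a number 0.30 log units higher from compound 2 to compound 4 (within the scatter) and supports no order between those two, and nothing in the data on hand accounts for any of these steps.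

The compounds shown leave open whether the low number of compound 3 belongs to methylsulfonyl alone or recurs with other groups on the same amine nitrogen, such as acetyl or a longer sulfonyl chain like ethylsulfonyl. They also leave open how a free primary amine at this place would read against compound 4 and compound 3 in this assay on the same scale.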